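Furan-2-yl in Place of Phenyl: What to Expect

The compounds below may be only part of what the source reports. "The series", "measured", "known", "first", "only" and "open" are said of these compounds alone.

Compound 2 `CC(C)(C)Cc1c(-c2ccccc2)sc(N)c1C(=O)c1ccc(Cl)cc1` stands level with compound 1 `CC(C)(C)Cc1c(-c2cccnc2)sc(N)c1C(=O)c1ccc(Cl)cc1`: in an assay on CHO cells for displacement of a labelled ligand from adenosine receptor A1 (Homo sapiens), read by scintillation counting, tested at 10 uM (a higher number here means more inhibition at the concentration tested (going by the name of the read-out), a lower number less inhibition), compound 2 gives 1%, and compound 1 gives 1%, so the step of no change at the digits printed from compound 1 to compound 2 (within the scatter) is the only one measured. Compound 3 `CC(C)(C)Cc1c(-c2ccco2)sc(N)c1C(=O)c1ccc(Cl)cc1` differs from compound 2 by furan-2-yl in place of phenyl on an aromatic carbon. That earlier step also swapped one aromatic ring for another at this same place and stayed within the scatter, so the step of a number 1 percentage points higher from compound 2 to compound 3 (within the scatter) is expected to be none beyond the scatter. Compound 3 is therefore estimated at 2%, ranging from -6% to 12%.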

Compound 3, a percentage reported as inhibition, at one concentration (the size of the read-out at that concentration, not a potency): 1%
Estimate against measurement, compound 3: 1 percentage points above; the range from low to high includes it.
By their numbers in this assay, from the lowest: compounds 1, 2 and 3 (each within the scatter of the next).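

Replacing a six-membered aromatic ring with the five-membered furan-2-yl gives no change at the digits printed from compound 2 to compound 3 (within the scatter) and, measured against pyridin-3-yl, no change at the digits printed from compound 1 to compound 3 (within the scatter). At this place next to the ring sulfur, neither the change in ring size nor the ring oxygen with its hydrogen-bond acceptor separates the compounds in this assay. No supporting data bear on this result. The compounds shown leave open whether any group at this place moves the reading at all. A non-aromatic group there, such as an amine or a carboxylic acid, remains untested in what is shown here, as does a longer chain in place of the neopentyl group.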